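Methylsulfanyl for Ethyl: a Small Change on the Ring

The source may hold more compounds than are shown below. What is called first, only, known or untested is meant among the compounds shown, and "the series" means these compounds.

Of the compounds shown here, two sharing one core have been tested in a functional assay on HEK293 cells for agonist activity at D(4) dopamine receptor (Homo sapiens), read by FLIPR; a higher number here means that more compound is needed for the effect, a lower number that less compound is needed. Compound 1 `CCc1cccc(NC(=O)CN2CCC(c3cccc[n+]3[O-])CC2)c1` gives 95 nM in this assay. Compound 2 `Cc1cc(C)cc(C(=O)NCN2CCC(c3cccc[n+]3[O-])CC2)c1` gives 90 nM in this assay. Of the two numbers, compound 1 stands at the higher one, but the gap to compound 2 lies within the usual scatter, so the two are taken as equivalent.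

The next compound, compound 3 `CSc1cccc(NC(=O)CN2CCC(c3cccc[n+]3[O-])CC2)c1`, has not yet been measured. It differs from compound 1 at one place only:

methylsulfanyl in place of ethyl on an aromatic carbon

The ethyl group leaves and a methylsulfanyl group enters, on an aromatic carbon of a six-membered aromatic ring of carbon only, meta to a large group; the rest of the molecule is unchanged.

Among the measured compounds shown here, no measured pair in this set shows what such a swap does. The two groups match in heavy-atom count and differ in one acceptor, so the step from compound 1 to compound 3 is expected to be small, a 1.2-fold lower number from compound 1 to compound 3 (0.07 log units; within the scatter), and may well fall within the scatter. Compound 3 is therefore estimated at 80 nM, in a range from 30 nM to 250 nM.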

Compound 3, half-maximal effective concentration: 100 nM
Compound 3: the middle estimate sits 1.3-fold (0.10 log units) below what was measured, and the stated range covers the measured number.
By their numbers in this assay, from the lowest: compounds 2, 1 and 3 (each within the scatter of the next).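

In this assay, putting methylsulfanyl in place of ethyl on an aromatic carbon, meta to a large group, gives a 1.1-fold higher number from compound 1 to compound 3 (0.02 log units; within the scatter), so this first measured pair for the change shows the two compounds to be equivalent. The earlier compounds shown here could not show this, as compound 1 and compound 2 differ in more than one place and offered no single step at this position. The swap from 3-ethylphenyl to 3-(methylsulfanyl)phenyl keeps the count of heavy atoms, brings in a sulfur and adds one hydrogen-bond acceptor, yet in this one pair that difference does not carry the number beyond the scatter, and nothing at hand offers an account of this equivalence.

What the compounds shown leave open is how far this tolerance extends, since a single pair cannot say whether a methoxy group, a chlorine atom or a longer chain such as propyl on the same aromatic carbon would also stay within the scatter. Going by these compounds, it also remains open whether methylsulfanyl would behave the same way on another carbon of the ring, or with a different group in place of the amide linkage of the shared core.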